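Swapping Nitro for Chloro: an Expected Loss

The source may report more compounds than this note shows. Statements on the series, on what has been measured and on what is new or still open speak of the compounds shown alone.

Compound 2 `O=C(/C=C/c1ccc([N+](=O)[O-])cc1)c1ccc[nH]1` gives 14000 nM in a functional assay on HL-60 cells (Homo sapiens) for inhibition, read by MTT assay, with a stated time of 48 h (on this read-out higher numbers stand for weaker inhibition and lower numbers for stronger inhibition), the only numeric reading shown. Compound 1 `O=C(/C=C/c1ccccc1)c1ccc[nH]1` sits at a limit, > 100000 nM (the limit of > 100000 nM in this assay, at which 1 of the 2 values shown sits), in this assay. Compound 3 `O=C(/C=C/c1ccc(Cl)cc1)c1ccc[nH]1` carries chloro in place of nitro on an aromatic carbon. Among the compounds with values here, the only measured step, an at least 7.1-fold lower number from compound 1 to compound 2 (0.85 log units; beyond the scatter), shows that putting nitro in brought the number down, so taking it away is expected to push the number back up, with chloro of unknown weight, and the expected step is a 2.9-fold higher number from compound 2 to compound 3 (0.46 log units; beyond the scatter). Compound 3 is therefore estimated at 40000 nM, within 10000 nM to 100000 nM.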

Compound 3, half-maximal inhibitory concentration: 13000 nM
Compound 3: the middle estimate sits 3.1-fold (0.49 log units) above what was measured; low and high end bracket the measured number.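

In this assay, chloro in place of nitro gives a 1.1-fold lower number from compound 2 to compound 3 (0.03 log units; within the scatter), so at this position the two groups cannot be told apart, although they differ in heavy atoms and hydrogen-bond acceptors. Chloro in place of hydrogen gives an at least 7.6-fold lower number from compound 1 to compound 3 (0.88 log units; beyond the scatter), so the drop at this position is not confined to nitro. Compound 1 stands at a limit, so the full size of this step stays unknown: the limit of > 100000 nM in this assay, at which 1 of the 3 values shown sits.

From the compounds shown here alone, whether an amine or a methoxy group at this position would also bring the number down stays open. So does whether chloro would do the same elsewhere on the ring.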